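From but-2-en-1-yl to pent-2-en-1-yl on the shared core

The source may hold more compounds than are shown below. What is called first, only, known or untested is meant among the compounds shown, and "the series" means these compounds.

Compound 1 `CCN1C(=O)[C@@H](C)NC(=O)[C@@H]2Cc3ccc(OC)c(c3)Oc3ccc(cc3)C[C@@H](C(=O)N2C)N(C)C(=O)[C@H](C)NC(=O)[C@H](Cc2ccc(OC)cc2)N(C)C(=O)[C@@H]1C` gives 43.7 nM
Compound 2 `C/C=C/CN1C(=O)[C@@H](C)NC(=O)[C@@H]2Cc3ccc(OC)c(c3)Oc3ccc(cc3)C[C@@H](C(=O)N2C)N(C)C(=O)[C@H](C)NC(=O)[C@H](Cc2ccc(OC)cc2)N(C)C(=O)[C@@H]1C` gives 9.12 nM

Both were tested in a functional assay on P388 cells (Mus musculus) for cytotoxicity (on this read-out lower numbers stand for stronger inhibition and higher numbers for weaker inhibition), and compound 2 holds the lower number at 9.12 nM so far. Compound 3 `CC/C=C/CN1C(=O)[C@@H](C)NC(=O)[C@@H]2Cc3ccc(OC)c(c3)Oc3ccc(cc3)C[C@@H](C(=O)N2C)N(C)C(=O)[C@H](C)NC(=O)[C@H](Cc2ccc(OC)cc2)N(C)C(=O)[C@@H]1C` differs from it by methyl in place of hydrogen on a saturated chain carbon bound to a double-bonded chain carbon as methyl in place of hydrogen on a saturated chain carbon bound to a double-bonded chain carbon. Among the compounds with values here, the one measured step bearing on this is a 4.8-fold lower number from compound 1 to compound 2 (0.68 log units; beyond the scatter) and it is modest. The new change is smaller, so no step beyond the scatter is expected. The estimated step is a 1.1-fold lower number from compound 2 to compound 3 (0.06 log units; within the scatter) in this read-out. Compound 3 is estimated at 8 nM with an expected range of 3 nM to 22 nM around it.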

Compound 3, half-maximal inhibitory concentration: 12 nM
Estimate against measurement, compound 3: 1.5-fold (0.18 log units) below; the range from low to high includes it.
By their numbers in this assay, from the lowest: compounds 2 and 3 (each within the scatter of the next); then compound 1.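

On this assay methyl in place of hydrogen on a saturated chain carbon bound to a double-bonded chain carbon stays within the scatter (a 1.3-fold higher number from compound 2 to compound 3 (0.12 log units; within the scatter)), so but-2-en-1-yl and pent-2-en-1-yl are not told apart at this position. The longer chain also keeps the lower number against the short saturated one (a 3.6-fold lower number from compound 1 to compound 3 (0.56 log units; beyond the scatter)). No measurement shown here accounts for either result. Still open, on these data alone, is whether a longer chain such as hept-2-en-1-yl, or a benzyl group or an amine in this place, would stay at this level.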